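The source may report more compounds than this note shows. Statements on the series, on what has been measured and on what is new or still open speak of the compounds shown alone.

Measured so far in an ADME assay on the whole organism (plasma, Rattus norvegicus) for protein binding, using cassette dosing, at a dose of 1 mg/kg; a higher number here means a larger unbound share of the compound, a lower number a smaller unbound share (unbound fraction):
- Compound 1 (`Cc1cc(/N=c2\[nH]c(=O)n(C[C@H](C)C(=O)O)c(=O)n2Cc2ccc(Cl)cc2)ccc1OC(C)C`): 0.02
- Compound 2 (`C[C@@H](Cn1c(=O)[nH]/c(=N\c2ccc(Oc3ccc(F)cn3)cc2)n(Cc2ccc(Cl)cc2)c1=O)C(=O)O`): 0.011

Among the compounds with values here, compound 2 sits within the scatter of compound 1, so these two numbers set no order between the compounds. Next in line is compound 3 (`C[C@@H](Cn1c(=O)[nH]/c(=N\c2ccc(Oc3cccc(F)n3)cc2)n(Cc2ccc(Cl)cc2)c1=O)C(=O)O`), which has not yet been measured in this assay and differs from compound 2 in one place (6-fluoropyridin-2-yl in place of 5-fluoropyridin-2-yl on an oxygen on an aromatic ring). It carries 6-fluoropyridin-2-yl in place of 5-fluoropyridin-2-yl on an oxygen on an aromatic ring. Within the data shown here, no measured pair differs in one place, so nothing yet tests this change directly. The expected 1.1-fold higher number from compound 2 to compound 3 (0.04 log units; within the scatter) stays within the scatter, with no direction favoured. The starting point is compound 2 (0.011). The estimate for compound 3 is 0.012 (expected range 0.006 to 0.024).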

Compound 3, unbound fraction: 0.007
For compound 3 the middle estimate is 1.7-fold (0.23 log units) above the measured one; low and high end bracket the measured number.
By their numbers in this assay, from the lowest: compounds 3, 2 and 1 (each within the scatter of the next, the first and the last beyond it).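

Within the data shown here, exchanging 5-fluoropyridin-2-yl for 6-fluoropyridin-2-yl on an oxygen on an aromatic ring gives a 1.6-fold lower number from compound 2 to compound 3 (0.20 log units; within the scatter) in this assay and is the first direct reading of this change. Compound 2 and compound 3 carry the same atoms, joined differently, and these numbers do not set the two apart, so moving the fluorine within the pyridine ring has no readable effect here. No measurement at hand bears on this result.

Still open, going by these compounds, is whether a different group on this oxygen, such as pyrimidin-2-yl or unsubstituted phenyl, would give a step beyond the scatter. The compounds shown also leave open what a primary amide or a tetrazole in place of the carboxylic acid would do to the unbound fraction.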